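A few compounds are considered here, and "the series" means these few. Any claim that something is new, unique, unknown or untested is made for them only; others in the source may bear on it.

Measured so far in a functional assay on A549 cells (Homo sapiens) for cytotoxicity, read by sulforhodamine B assay, with a stated time of 48 h; on this read-out lower numbers stand for stronger inhibition and higher numbers for weaker inhibition:
- Compound 1 `O=c1[nH]c(N/N=C/c2ccc(Cl)cc2)nc2nc(-c3cccs3)cc(-c3ccccc3)c12`: 40800 nM
- Compound 2 `Cc1ccc(/C=N/Nc2nc3nc(-c4cccs4)cc(-c4ccccc4)c3c(=O)[nH]2)cc1`: 56600 nM

Only these two compounds have been measured, and they share the same core. Within the data shown here, compound 2, at 56600 nM, cannot be separated from compound 1, since the one measured step is a 1.4-fold higher number from compound 1 to compound 2 (0.14 log units; within the scatter). That step exchanges chloro for methyl on an aromatic carbon.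

Compound 3 `COc1ccc(/C=N/Nc2nc3nc(-c4cccs4)cc(-c4ccccc4)c3c(=O)[nH]2)cc1` has not yet been measured in this assay. It differs from compound 2 by methoxy in place of methyl on an aromatic carbon. This is methoxy in place of methyl on an aromatic carbon, turning 4-methylphenyl into 4-methoxyphenyl.

Among the measured compounds shown here, the sole guide is the exchange on that same ring, a 1.4-fold higher number from compound 1 to compound 2 (0.14 log units; within the scatter). For the measured compounds named here, one step is thin evidence, and no measured compound yet carries a methoxy group. Nothing in the data therefore points to a direction, and no shift beyond the scatter is expected.

The expected change is a 1.2-fold lower number from compound 2 to compound 3 (0.07 log units; within the scatter). For compound 3 the estimated value is 48000 nM, with an expected range from 24000 nM to 95000 nM.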

Compound 3, half-maximal inhibitory concentration: 18700 nM
The estimate for compound 3 lay 2.6-fold (0.41 log units) above the measured number; the whole stated range lies above it.
By their numbers in this assay, from the lowest: compound 3; then compounds 1 and 2 (each within the scatter of the next).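

In this assay, the position para to a large group on the six-membered aromatic ring of carbon only proves able to respond to its substituent, which the exchange of chloro for methyl alone could not show: methoxy in place of methyl gives a 3.0-fold lower number from compound 2 to compound 3 (0.48 log units; beyond the scatter), and methoxy in place of chloro gives a 2.2-fold lower number from compound 1 to compound 3 (0.34 log units; beyond the scatter). Both steps are modest but lie beyond the scatter, so compound 3 is the most potent of the three, and the change to methoxy stands apart from two groups that could not be separated from each other. The data shown hold no measurement that would account for this difference.

As far as these compounds go, what a hydroxy group, an ethoxy group or an amine would do at this same place remains open, and with it whether the shift belongs to methoxy alone or extends to related groups. From the compounds shown here alone, it is also open whether methoxy would give a step of similar size elsewhere on this ring or on a different core.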